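A Cyanophenyl Swap on a Weakly Active Compound

The source may report more compounds than this note shows. Statements on the series, on what has been measured and on what is new or still open speak of the compounds shown alone.

- compound 1 `COc1cc(-c2cc3nccc(-c4cc(OC)c(OC)c(OC)c4)n3n2)cc(OC)c1OC` gives > 10000 nM
- compound 2 `COc1cc(-c2ccnc3cc(-c4ccc(F)cc4)nn23)cc(OC)c1OC` gives 4540 nM

In a functional assay on B16-F0 cells (Mus musculus) for inhibition, read by CCK-8 assay, with a stated time of 48 h (on this read-out lower numbers stand for stronger inhibition and higher numbers for weaker inhibition), compound 1 gives > 10000 nM as a limit and not a number. Among the compounds with values here, compound 2 gives 4540 nM as the only actual number so far. Compound 3 `COc1cc(-c2ccnc3cc(-c4cccc(C#N)c4)nn23)cc(OC)c1OC` changes one group of compound 2, with 3-cyanophenyl in place of 4-fluorophenyl on an aromatic carbon. Within the data shown here, no measured pair shows what such a swap does, so no shift beyond the usual scatter in this assay is expected, and the expected step is a 1.3-fold lower number from compound 2 to compound 3 (0.11 log units; within the scatter). For compound 3 the estimated value is 3500 nM, with an expected range of 800 nM to 10000 nM.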

Compound 3, half-maximal inhibitory concentration: > 10000 nM
Compound 3: only a limit was reported (the forecaster's own chance of this, stated with the estimate: 25%); at least 2.8-fold (0.45 log units) between middle value and limit.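

Moving from 4-fluorophenyl to 3-cyanophenyl on this aromatic carbon of the five-membered ring gives an at least 2.2-fold higher number from compound 2 to compound 3 (0.34 log units; beyond the scatter) in this assay. Within the data shown here, this is the first sign that the group at this place affects the read-out, and here the change goes against activity. As far as these compounds go, compound 3 gives > 10000 nM, which is a limit and not a number, so the true size of the step stays unknown: the limit of > 10000 nM in this assay, at which 2 of the 3 values shown sit.

The nitrile and its place on the phenyl ring cannot be told apart here. From the compounds shown here alone, whether an unsubstituted phenyl group, or a phenyl group carrying an amine or a carboxylic acid, would do better at this place stays open.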